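Working notes: from compound 3 to compound 4

The compounds below may be only part of what the source reports. "The series", "measured", "known", "first", "only" and "open" are said of these compounds alone.

Measured in a physicochemical assay for solubility, in phosphate buffer, at pH 7.4; on this read-out lower numbers stand for lower solubility and higher numbers for higher solubility:
- compound 1 `OCC1CCN(c2nccnc2Oc2ccc(Nc3nc4ccccc4s3)cc2)CC1` gives 6000 nM
- compound 2 `OCC1CCN(c2cccnc2OC2CN(c3ccc4ccccc4n3)C2)CC1` gives 189000 nM
- compound 3 `OCCC1CCN(c2nccnc2OC2CN(c3ccc4ccccc4n3)C2)CC1` gives 84000 nM

Compound 3 stands second highest of the three numbers, with compound 2 higher and compound 1 lower, both gaps beyond the scatter. Compound 4 `OC1CN(c2nccnc2OC2CN(c3ccc4ccccc4n3)C2)C1` carries 3-hydroxyazetidin-1-yl in place of 4-(2-hydroxyethyl)piperidin-1-yl on an aromatic carbon. Going by the values given here, no measured pair shows a change in this one place, so the expectation is loose. A modest upward step is expected (a 1.8-fold higher number from compound 3 to compound 4 (0.25 log units; within the scatter)), and a step within the scatter remains possible. For compound 4 the estimated value in this assay is 150000 nM (expected range 55000 nM to 400000 nM).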

Compound 4, solubility: 41000 nM
Estimate against measurement, compound 4: 3.7-fold (0.56 log units) above, outside the stated range (below it).
By their numbers in this assay, from the lowest: compound 1; then compound 4; then compound 3; then compound 2.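

In this assay, going by these compounds alone, 3-hydroxyazetidin-1-yl in place of 4-(2-hydroxyethyl)piperidin-1-yl on an aromatic carbon gives a 2.0-fold lower number from compound 3 to compound 4 (0.31 log units; beyond the scatter), the first single-place step. This position therefore moves the read-out, and the smaller group, with unchanged hydrogen-bond donor and acceptor counts, gives the lower number. No supporting measurement bears on the origin of this step.

As far as these compounds go, this one pair changes ring size and chain together, so their separate contributions remain open. From the compounds shown here alone, how a primary amine or a carboxylic acid would read out at this place also remains open.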